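Furan-2-yl aryl replacement at the double-bonded ring carbon

The compounds below may be only part of what the source reports. "The series", "measured", "known", "first", "only" and "open" are said of these compounds alone.

Measured in a functional assay on HCT-116 cells (Homo sapiens) for cytotoxicity; a higher number here means a weaker inhibitor, a lower number a stronger inhibitor:
compound 1 `COc1ccc(C2=C(c3ccccc3)C(=O)N3CCCC3C2)cc1` gives 390 nM
compound 2 `COc1ccc(C2=C(c3ccccn3)C(=O)N3CCCC3C2)cc1` gives 104000 nM
compound 3 `COc1ccc(C2=C(c3cccs3)C(=O)N3CCCC3C2)cc1` gives 5000 nM

Compound 2 stands highest of the three numbers in this assay; its nearest neighbour is compound 3 at a 21-fold lower number from compound 2 to compound 3 (1.32 log units; beyond the scatter), and compound 1 lies furthest at a 270-fold higher number from compound 1 to compound 2 (2.43 log units; beyond the scatter). Compound 4 `COc1ccc(C2=C(c3ccco3)C(=O)N3CCCC3C2)cc1` is not yet measured. It differs from compound 2 as follows: furan-2-yl in place of pyridin-2-yl on a double-bonded ring carbon.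

For the measured compounds named here, the step bearing most directly on this is the one from compound 2 to compound 3, which exchanges pyridin-2-yl for another five-membered aromatic ring with one hetero atom and gives a 21-fold lower number from compound 2 to compound 3 (1.32 log units; beyond the scatter). The step of a 13-fold higher number from compound 1 to compound 3 (1.11 log units; beyond the scatter) shows the five-membered ring still well above phenyl. A large downward step is therefore expected in this assay, a 13-fold lower number from compound 2 to compound 4 (1.11 log units; beyond the scatter).

Compound 4 is estimated at 8000 nM, expected between 2000 nM and 40000 nM.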

Compound 4, half-maximal inhibitory concentration: 6000 nM
The estimate for compound 4 lay 1.3-fold (0.12 log units) above the measured number; low and high end bracket the measured number.
By their numbers in this assay, from the lowest: compound 1; then compounds 3 and 4 (each within the scatter of the next); then compound 2.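

In this assay the gain over pyridin-2-yl is not peculiar to thiophen-2-yl: furan-2-yl gives a 17-fold lower number from compound 2 to compound 4 (1.24 log units; beyond the scatter) in the same direction. The exchange of sulfur for oxygen in the five-membered ring, with a 1.2-fold higher number from compound 3 to compound 4 (0.08 log units; within the scatter) and so within the scatter, leaves the number effectively unchanged, while furan-2-yl still falls well short of phenyl, with a 15-fold higher number from compound 1 to compound 4 (1.19 log units; beyond the scatter) in this assay as well. No evidence at hand accounts for these differences between the rings.

Open, on these data alone, is whether pyridin-3-yl or pyridin-4-yl at this carbon behaves like pyridin-2-yl. Also open, as far as these compounds go, is whether a fluorine or an amine on the phenyl ring of compound 1 is tolerated.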